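Chloro for Bromo on a Sulfonamide Chain

The source may hold more compounds than are shown below. What is called first, only, known or untested is meant among the compounds shown, and "the series" means these compounds.

Compound 1, `O=S(=O)(NCCCCNCc1ccc(Br)cc1)c1cc(C(F)(F)F)cc(C(F)(F)F)c1`: in a functional assay on HT-29 cells (Homo sapiens) for inhibition, read by MTT assay, with a stated time of 72 h (on this read-out higher numbers stand for weaker inhibition of growth and lower numbers for stronger inhibition of growth), compound 1 gives 1600 nM.
Compound 2, `O=S(=O)(NCCCNCC1COc2ccccc2O1)c1cc(C(F)(F)F)cc(C(F)(F)F)c1`: compound 2 gives 2200 nM.
Compound 3, `O=S(=O)(NCCCNCc1ccc(Br)cc1)c1cc(C(F)(F)F)cc(C(F)(F)F)c1`: compound 3 gives 2200 nM.

Compound 3 stands level with compound 2, and the two together hold the highest numbers of the three. Compound 1 lies furthest from compound 3, yet the step of a 1.4-fold higher number from compound 1 to compound 3 (0.14 log units; within the scatter) is a small one. The other step, no change at the digits printed from compound 2 to compound 3 (within the scatter), shows that exchanging the whole ring group bound to the amine nitrogen left the number where it was.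

Compound 4, `O=S(=O)(NCCCNCc1ccc(Cl)cc1)c1cc(C(F)(F)F)cc(C(F)(F)F)c1`, has not yet been measured. It differs from compound 3 in one place: chloro in place of bromo on an aromatic carbon. Neither measured step touches this halogen position directly, so the best guide is the general picture, in which both a change of chain length and a change of the ring group stayed within the scatter. A swap of one halogen for another at the same position is therefore expected to give no change beyond the scatter, no change at the digits printed from compound 3 to compound 4 (within the scatter). For compound 4 the expected value in this assay is 2200 nM, with a range from 1100 nM to 4400 nM.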

Compound 4, concentration for 50% growth inhibition: 2800 nM
Compound 4: middle estimate off by 1.3-fold (0.10 log units), on the low side, and the stated range covers the measured number.
By their numbers in this assay, from the lowest: compounds 1, 2, 3 and 4 (each within the scatter of the next).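

Going by these compounds alone, compound 4 offers the one direct comparison at the halogen on the aromatic ring: in this assay the swap gives a 1.3-fold higher number from compound 3 to compound 4 (0.10 log units; within the scatter), so at this place, para to a large group, chloro and bromo cannot be told apart. The chloro compound also sits close to the compounds that differ further, with a 1.3-fold higher number from compound 2 to compound 4 (0.10 log units; within the scatter) when the ring group is exchanged and a 1.8-fold higher number from compound 1 to compound 4 (0.24 log units; within the scatter) when the chain and the halogen differ together, so even this two-part difference does not separate the compounds. No measurement at hand offers an explanation for how little these numbers move.

From the compounds shown here alone, two halogens at one position say little about that position as a whole, so it remains open whether a plain hydrogen, a fluoro, a methoxy or a nitrile there would stay in the same range. Also open, going by these compounds, is whether a clearer difference would appear with a longer chain, or with an amide in place of the amine nitrogen, since every compound here keeps that amine and the two trifluoromethyl groups.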